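Shortening the chain and capping the amide

This account rests on a few compounds, and the source may have more. Where it says the series, first, only, none or still open, it means among the compounds named here.

Compound 1, `NC(=O)CCCCc1c[nH]c2ccc(F)cc12`, holds the lowest of the two numbers seen so far: in an assay on isolated protein (urine) for inhibition of Myeloperoxidase (Homo sapiens), with a stated time of 5 min (on this read-out higher numbers stand for weaker inhibition and lower numbers for stronger inhibition), compound 1 gives 39 nM. Compound 3, `NC(=O)CCc1c[nH]c2ccc(F)cc12`, gives 132 nM in this assay and is the nearest neighbour of compound 1. Compound 2, `NCCSCCCc1c[nH]c2c(F)cccc12`, reaches only a limit of the assay, > 100 nM in this assay, and so contributes no number.

A single step has been measured among these compounds: a 3.4-fold higher number from compound 1 to compound 3 (0.53 log units; beyond the scatter). Shortening the chain that carries the amide thus weakens inhibition to a modest degree.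

Compound 4, `CCNC(=O)CCCc1c[nH]c2ccc(F)cc12`, differs from compound 1 by ethylcarbamoyl in place of carbamoylmethyl on a saturated chain carbon, three bonds along the chain from an aromatic carbon. The chain to the amide is again shorter, though by less than in the step to compound 3, and an ethylcarbamoyl group replaces the plain amide. For the measured compounds named here, no measured pair shows what the ethylcarbamoyl group alone does, so the step to compound 3 remains the only guide. A weakening smaller than that step is therefore expected, a 2.1-fold higher number from compound 1 to compound 4 (0.31 log units; beyond the scatter). Compound 4 is accordingly estimated to give 80 nM in this assay, with a likely range from 30 nM to 220 nM.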

Compound 4, half-maximal inhibitory concentration: 182 nM
For compound 4 the middle estimate is 2.3-fold (0.36 log units) below the measured one; the measured number falls inside the stated range.
By their numbers in this assay, from the lowest: compound 1; then compounds 3 and 4 (each within the scatter of the next).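

In this assay, ethylcarbamoyl in place of carbamoylmethyl on a saturated chain carbon, three bonds along the chain from an aromatic carbon, gives a 4.7-fold higher number from compound 1 to compound 4 (0.67 log units; beyond the scatter) and so provides a second change at the end of the chain that moves away from the low number of compound 1. Set against the shorter plain amide, the same compound shows a 1.4-fold higher number from compound 3 to compound 4 (0.14 log units; within the scatter) and thus (ethylcarbamoyl)methyl in place of carbamoyl brings no change that can be told apart from the usual scatter. Compound 1 therefore stands apart from both compound 3 and compound 4, but nothing measured here accounts for this.

Compound 2 stands at > 100 nM which is a limit of the assay and not a number, so it offers nothing to place in this order. As far as these compounds go, what the ethyl group on the amide nitrogen does with the chain length held fixed remains open, as does whether a longer chain or a carboxylic acid at the chain end would hold or lower the number of compound 1.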